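From Compound 2 to Compound 3 in Rats

The source may hold more compounds than are shown below. What is called first, only, known or untested is meant among the compounds shown, and "the series" means these compounds.

Of the compounds shown here, two on a shared core have been tested in a functional assay on the whole organism for antagonist activity, with Rattus norvegicus as the target; a higher number here means that more compound is needed for the effect, a lower number that less compound is needed. Compound 1 `C1=C(CCN2CCN(c3cccc4c3OCCO4)CC2)c2ccccc2CCC1` gives 5.02 mg/kg in this assay. Compound 2 `c1ccc2c(c1)CC(CCCN1CCN(c3cccc4c3OCCO4)CC1)C2` gives 0.47 mg/kg in this assay, the lowest of the two numbers; its gap to compound 1 is beyond the usual scatter of repeated measurements. Compound 3 `Clc1cccc2c1CC2CCCN1CCN(c2cccc3c2OCCO3)CC1` has not yet been measured in this assay. It differs from compound 2 in one place: a group of 9 heavy atoms (8 carbon, 1 chlorine; one four-membered non-aromatic ring of carbon only, one six-membered aromatic ring of carbon only) in place of a group of 9 heavy atoms (9 carbon; one five-membered non-aromatic ring of carbon only, one six-membered aromatic ring of carbon only), on a saturated chain carbon, three bonds along the chain from an amine nitrogen in a ring. The 2,3-dihydro-1H-inden-2-yl group thus leaves, and a group with one four-membered non-aromatic ring and one chlorine enters on the same saturated chain carbon. Going by the values given here, no two measured compounds differ in one place alone, so the two known values give no direct reading of what such an exchange does. Compound 2 remains the nearest measured point, and the step from it to compound 3 is expected to stay small, most likely within the scatter, as a 1.3-fold higher number from compound 2 to compound 3 (0.11 log units; within the scatter). Compound 3 is therefore estimated at 0.6 mg/kg, with a likely range from 0.2 mg/kg to 2 mg/kg.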

Compound 3, dose for 50% inhibition: 3.09 mg/kg
Beside the measured number, compound 3's estimate is 5.2-fold (0.71 log units) below it; measured number outside the range, above it.
By their numbers in this assay, from the lowest: compound 2; then compounds 3 and 1 (each within the scatter of the next).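

In this assay, going by these compounds alone, the exchange on this saturated chain carbon, three bonds along the chain from an amine nitrogen in a ring, gives the first reading of a change in one place, and the result is a 6.6-fold higher number from compound 2 to compound 3 (0.82 log units; beyond the scatter). The position therefore responds to what it carries, even though the entering group matches the 2,3-dihydro-1H-inden-2-yl group in its 9 heavy atoms, its 0 hydrogen-bond donors and acceptors, and its lack of net charge, so these matching counts alone do not keep the number in place. No measurement at hand bears on what lies behind this shift.

The four-membered non-aromatic ring and the chlorine enter together in this single step, so the compounds shown cannot separate the share of the ring from the share of the chlorine. Also open, going by these compounds, is how a fluorine or a methyl group in place of the chlorine, or a longer chain leading to the amine nitrogen, would read in this assay.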